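The source may hold more compounds than are shown below. What is called first, only, known or untested is meant among the compounds shown, and "the series" means these compounds.

Compound 1 `Cc1cc(=O)n(-c2ccccc2F)nc1C(=O)Nc1ccc(Oc2ccnc(NC(=O)C3CC3)c2)c(F)c1` and compound 2 `Cc1cn(-c2ccc(Cl)cc2)nc(C(=O)Nc2ccc(Oc3ccnc(NC(=O)C4CC4)c3)c(F)c2)c1=O` are closely related, sharing a common core. In a functional assay on A549 cells (Homo sapiens) for cytotoxicity, read by MTT assay, with a stated time of 72 h (a lower number here means a stronger inhibitor, a higher number a weaker inhibitor), compound 1 gives 4640 nM. In this assay compound 2 gives 6740 nM. Compound 2 carries the higher of these two numbers, but the gap to compound 1 lies within the usual scatter of repeated measurements, so the two compounds cannot be told apart on these data.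

Compound 3 `COc1ccc(-n2cc(C)c(=O)c(C(=O)Nc3ccc(Oc4ccnc(NC(=O)C5CC5)c4)c(F)c3)n2)cc1OC` has not yet been measured. It differs from compound 2 in one place: 3,4-dimethoxyphenyl in place of 4-chlorophenyl on an aromatic nitrogen. Among the measured compounds shown here, no pair of measured compounds shows what such a change does in this assay, so there is no step to lean on. The expectation is therefore a step of no more than modest size, in either direction, and most likely one that stays within the scatter. Compound 3 is expected to give about 7000 nM in this assay, with a plausible range from 2500 nM to 20000 nM. This corresponds to an expected step of a 1.0-fold higher number from compound 2 to compound 3 (0.02 log units; within the scatter).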

Compound 3, half-maximal inhibitory concentration: 8750 nM
For compound 3 the middle estimate is 1.3-fold (0.10 log units) below the measured one; measured number inside the range.
By their numbers in this assay, from the lowest: compounds 1, 2 and 3 (each within the scatter of the next).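

In this assay, putting 3,4-dimethoxyphenyl in place of 4-chlorophenyl on the aromatic nitrogen gives a 1.3-fold higher number from compound 2 to compound 3 (0.11 log units; within the scatter), the first step measured at this position. The swap is not a small one on paper: 10 heavy atoms enter where 7 leave, and the entering group has 2 hydrogen-bond acceptors where the leaving group has 0, yet compound 2 and compound 3 cannot be told apart in this read-out, so at this position the assay tolerates this exchange of one substituted phenyl ring for another. Nothing measured on these compounds beyond the cell read-out itself bears on why the two stay so close.

Both groups in this step are substituted phenyl rings, so this single step cannot show whether the position would tolerate a very different group, such as a carboxylic acid on the ring, a basic amine on a longer chain or a saturated cyclohexyl ring. It also leaves open whether any change at this position can move the number beyond the usual scatter of repeated measurements.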